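The source may hold more compounds than are shown below. What is called first, only, known or untested is meant among the compounds shown, and "the series" means these compounds.

In an ADME assay on S9 fraction from liver (Rattus norvegicus) for metabolic stability, with a stated time of 1 h (on this read-out higher numbers stand for a more stable compound and lower numbers for a less stable compound), compound 1 `N#Cc1cnc(NCc2cnccc2C(F)(F)F)cc1N[C@H]1C[C@H](O)C1` gives 82%, compound 2 `N#Cc1cnc(NCc2cnccc2C(F)(F)F)cc1NC[C@H]1C[C@H](O)C1` gives 61% and compound 3 `N#Cc1cnc(NCc2cnccc2C(F)(F)F)cc1N[C@H]1CC[C@@H](O)CC1` gives 6%, the lowest of the three. Compound 4 `CN(C)C(=O)[C@H]1CC[C@@H](Nc2cc(NCc3cnccc3C(F)(F)F)ncc2C#N)CC1` keeps the ring of compound 3 but carries dimethylcarbamoyl in place of hydroxy on a saturated ring carbon.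

The measured steps all change the group on the nitrogen, and each of these groups keeps its hydroxy. They run from a modest a number 21 percentage points lower from compound 1 to compound 2 (beyond the scatter) to the large a number 55 percentage points lower from compound 2 to compound 3 (beyond the scatter) and a number 76 percentage points lower from compound 1 to compound 3 (beyond the scatter). For the measured compounds named here, they show that this assay responds strongly to this part of the molecule, but none of them replaces the hydroxy, so the data offer no direct precedent for this change. Compound 3 at 6% leaves little room for a fall, so a modest rise is the likelier outcome. The expected change is a number 19 percentage points higher from compound 3 to compound 4 (beyond the scatter). For compound 4 the estimated value is 25%, with an expected range from 5% to 60%.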

Compound 4, percent of the compound remaining: 22%
Compound 4: middle estimate off by 3 percentage points, on the high side; measured number inside the range.
By their numbers in this assay, from the lowest: compound 3; then compound 4; then compound 2; then compound 1.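

In this assay, for the compounds shown here, this is the first change at the saturated ring carbon itself rather than in the group on the nitrogen, and it gives a number 16 percentage points higher from compound 3 to compound 4 (beyond the scatter). The read-out therefore also moves when the hydroxy is exchanged for dimethylcarbamoyl, a group of five heavy atoms with no hydrogen-bond donor, and here that exchange costs nothing on this read-out. Nothing available explains the rise.

As far as these compounds go, it remains open whether the rise follows from losing the hydroxy or from the dimethylcarbamoyl itself, and whether a methoxy, a primary amide or a carboxylic acid on the same ring carbon would give a similar number. From the compounds shown here alone, it is equally open whether dimethylcarbamoyl would have a similar effect in place of the hydroxy of compound 1 or compound 2.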